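The compounds below may be only part of what the source reports. "The series", "measured", "known", "first", "only" and "open" are said of these compounds alone.

Measured so far in a physicochemical assay for solubility, at pH 7.4; on this read-out lower numbers stand for lower solubility and higher numbers for higher solubility:
compound 1 `Cc1cc(NC(=O)Nc2ccc(C(C)(C)C)cc2)c2ccccc2n1` gives 6200 nM
compound 2 `Cc1cc(NC(=O)Nc2ccccc2N)c2ccccc2n1` gives 51800 nM
compound 3 `Cc1cc(NC(=O)Nc2cc(F)cc(F)c2)c2ccccc2n1` gives 300 nM

On this read-out compound 1 stands second highest of the three numbers. Compound 2 is nearest to it, at a higher number, and compound 3 furthest, at a lower number; both gaps lie beyond the usual scatter. Compound 4 `Cc1cc(NC(=O)Nc2ccc(C(N)=O)cc2)c2ccccc2n1` has not yet been measured in this assay. It differs from compound 1 in one place: carbamoyl in place of tert-butyl on an aromatic carbon. Within the data shown here, no step between measured compounds mirrors this change, so its size rests on expectation alone. An upward step in this assay, beyond the scatter, is expected: a 3.2-fold higher number from compound 1 to compound 4 (0.51 log units; beyond the scatter). Compound 4 is accordingly estimated at 20000 nM, with a likely range from 5000 nM to 80000 nM.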

Compound 4, solubility: 900 nM
Compound 4: the middle estimate sits 22-fold (1.35 log units) above what was measured; the whole stated range lies above it.
By their numbers in this assay, from the lowest: compound 3; then compound 4; then compound 1; then compound 2.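

Carbamoyl in place of tert-butyl on this aromatic carbon, para to a large group, gives a 6.9-fold lower number from compound 1 to compound 4 (0.84 log units; beyond the scatter) in this assay and is the first step read at this position. In this pair, the entering group with a hydrogen-bond donor and acceptor sits on the lower side, so those counts do not carry the number upward here. Nothing at hand accounts for the direction of this step.

Open, as far as these compounds go, is where an amine, a carboxylic acid or a nitrile on the same aromatic carbon would fall relative to compound 1 and compound 4. Also open, from the compounds shown here alone, is how either group compares with an unsubstituted carbon at this position.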